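The source may hold more compounds than are shown below. What is called first, only, known or untested is meant among the compounds shown, and "the series" means these compounds.

In a functional assay on A-375 cells (Homo sapiens) for antiproliferative activity, read by CCK-8 assay, with a stated time of 72 h (a higher number here means a weaker inhibitor, a lower number a stronger inhibitor), compound 1 `CCc1ccc(SCc2ccc(/C=C/C(=O)Nc3ccccc3N)cc2)cc1` stands at "not determined" (no result reported) and so offers no number to start from. For the measured compounds named here, the change to compound 4 `CC(C)(C)c1ccc(SCc2ccc(/C=C/C(=O)Nc3ccccc3N)cc2)cc1` is tert-butyl in place of ethyl on an aromatic carbon, para to a large group: tert-butyl in place of ethyl on an aromatic carbon and no measured pair covers this exchange. The nearest evidence is compound 2 `COc1ccc(SCc2ccc(C(=O)Nc3ccccc3N)cc2)cc1` at 3010 nM and compound 3 `COc1ccc(SCc2ccc(C(=O)Nc3ccccc3N)cc2)cc1OC` at 4420 nM and both have a core that differs from that of compound 1. Going by the values given here, their one step of a 1.5-fold higher number from compound 2 to compound 3 (0.17 log units; within the scatter) involves methoxy in place of hydrogen on an aromatic carbon. A step beyond the scatter is therefore not expected from this kind of exchange, and no direction can be favoured, although the differing core widens the uncertainty. Compound 4 is estimated at 2200 nM with an expected range from 450 nM to 9000 nM for repeated measurements.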

Compound 4, half-maximal inhibitory concentration: 1550 nM
Compound 4: middle estimate off by 1.4-fold (0.15 log units), on the high side; the range from low to high includes it.
By their numbers in this assay, from the lowest: compounds 4, 2 and 3 (each within the scatter of the next, the first and the last beyond it).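

For the compounds shown here, with compound 1 at "not determined" (no result reported) in this assay no step from it to compound 4 can be read. From the compounds shown here alone, how tert-butyl in place of ethyl shifts the number on this core stays open. No evidence at hand bears on this result.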